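Thiourea aryl substitution and cytotoxicity toward dog kidney cells

A few compounds are considered here, and "the series" means these few. Any claim that something is new, unique, unknown or untested is made for them only; others in the source may bear on it.

Compound 1 `CCN(CC)CN1C(=O)/C(=N/NC(N)=S)c2cc(Cl)ccc21` is the gentler of the two measured compounds in an ADME assay on MDCK cells (Canis lupus familiaris) for cytotoxicity (on this read-out lower numbers stand for higher toxicity in this test and higher numbers for lower toxicity in this test), giving 100000 nM. Compound 2 `CCN(CC)CN1C(=O)/C(=N/NC(=S)Nc2ccccc2)c2ccccc21`, which carries a phenyl group on the thiourea nitrogen and lacks the chlorine, gives 800 nM in this assay. Compound 3 `CCN(CC)CN1C(=O)/C(=N/NC(=S)Nc2ccc(C)cc2)c2cc(Cl)ccc21` follows from compound 1 by one change: 4-methylphenyl in place of hydrogen on an amide-type nitrogen. A large downward step is expected, because compound 2 shows 800 nM once an aryl group sits on that nitrogen. Compound 3 is therefore estimated at 1500 nM, within 300 nM to 10000 nM, which means an expected 67-fold lower number from compound 1 to compound 3 (1.82 log units; beyond the scatter).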

Compound 3, minimum cytotoxic concentration: 4000 nM
For compound 3 the middle estimate is 2.7-fold (0.43 log units) below the measured one; the measured number falls inside the stated range.
By their numbers in this assay, from the lowest: compound 2; then compound 3; then compound 1.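

Compound 1 and compound 2 differ in two places, so the earlier values could not show what an aryl group on this nitrogen does by itself. With the chlorine kept in place, 4-methylphenyl in place of hydrogen on this amide-type nitrogen gives a 25-fold lower number from compound 1 to compound 3 (1.40 log units; beyond the scatter) in this assay, a large step toward higher toxicity in this test from this one change.

Compound 2 and compound 3 also differ in two places, which leaves the chlorine and the methyl unread on their own. How a butyl chain or a phenyl ring carrying a carboxylic acid would behave on this nitrogen stays open, and nothing measured here gives a reason for the step.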